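The source may hold more compounds than are shown below. What is called first, only, known or untested is meant among the compounds shown, and "the series" means these compounds.

Measured in a functional assay on HCT-116 cells (Homo sapiens) for antiproliferative activity, read by MTT assay, with a stated time of 72 h; on this read-out higher numbers stand for weaker inhibition and lower numbers for stronger inhibition:
Compound 1 `COc1cccc(N2C(=O)COc3ccc(-c4cnc5ccccc5c4)cc32)c1`: 8240 nM
Compound 2 `O=C1COc2ccc(-c3cnc4ccccc4c3)cc2N1c1ccc(F)cc1`: > 40000 nM

Compound 2 reads > 40000 nM, which is a limit of the assay and not a number. Compound 3 `O=C1COc2ccc(-c3cnc4ccccc4c3)cc2N1` keeps the shared core but carries hydrogen in place of 4-fluorophenyl on an amide-type nitrogen in a ring. Among the compounds with values here, one measured step bears on this place, an at least 4.8-fold higher number from compound 1 to compound 2 (0.68 log units; beyond the scatter), with 4-fluorophenyl in place of 3-methoxyphenyl. Within the data shown here, the group on this nitrogen can therefore shift the read-out beyond the scatter, although no measured compound lacks such a group. A modest move toward a lower number in this assay is expected, and staying at the limit remains possible. The expected change is an at least 2.2-fold lower number from compound 2 to compound 3 (0.34 log units; beyond the scatter). Compound 3 is estimated at 18000 nM, with an expected range of 5000 nM to 40000 nM.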

Compound 3, half-maximal inhibitory concentration: > 40000 nM
Compound 3: no number, only a limit (the forecaster's own chance of this, stated with the estimate: 35%); at least 2.2-fold (0.34 log units) between middle value and limit.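

In this assay, hydrogen in place of 3-methoxyphenyl on the amide-type nitrogen gives an at least 4.8-fold higher number from compound 1 to compound 3 (0.68 log units; beyond the scatter), so the shared core with no ring on this nitrogen does not keep the read-out of compound 1. Compound 3 reads > 40000 nM, which is a limit of the assay and not a number. Of the three groups shown on this nitrogen, only 3-methoxyphenyl gives a measured number, and the step between compound 2 and compound 3 cannot be read because both compounds sit at the limit: the limit of > 40000 nM in this assay, at which 2 of the 3 values shown sit.

On these data alone, how far compound 2 and compound 3 lie past the limit stays open, so 4-fluorophenyl and hydrogen cannot be ranked. Also open, as far as these compounds go, is how a plain phenyl, a 3-hydroxyphenyl or an ethyl chain on this nitrogen would read.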